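The source may hold more compounds than are shown below. What is called first, only, known or untested is meant among the compounds shown, and "the series" means these compounds.

Compound 1 `Cc1nc(C)c(Cn2ncc3c(Nc4ccc(OC(F)(F)F)cc4)ncnc32)s1`: > 10000 nM (a limit)
Compound 2 `OCCn1ncc2c(Nc3ccc(OC(F)(F)F)cc3)ncnc21`: > 10000 nM (a limit)

In an ADME assay on BaF3 cells (Mus musculus) for cytotoxicity (on this read-out lower numbers stand for an effect already at smaller amounts and higher numbers for an effect only at larger amounts of compound), compound 2 gives > 10000 nM, which is a limit of the assay and not a number. Compound 1 likewise gives only a limit, so neither compound has a true value, and the record so far is the limit of > 10000 nM in this assay, at which 2 of the 2 values shown sit.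

The next compound is compound 3 `FC(F)(F)Oc1ccc(Nc2ncnc3c2cnn3Cc2ccccc2)cc1`. It keeps the core of compound 2 but carries phenyl in place of hydroxymethyl on a saturated chain carbon bound to an aromatic nitrogen, so 2-hydroxyethyl becomes benzyl: phenyl in place of hydroxymethyl on a saturated chain carbon bound to an aromatic nitrogen.

Going by the values given here, only one measured step changes this same place, and that is a step that the two limits leave unreadable from compound 1 to compound 2. It offers no size to carry forward. It does show that compound 1, with its 2,4-dimethyl-1,3-thiazol-5-yl ring at this place, reached the same limit as compound 2. A ring here therefore gives no reason to expect a clear shift in either direction, though a single pair is thin support.

The expected change is a number no higher from compound 2 to compound 3 (the limit leaves the size open), with no readable direction. For compound 3 the estimated value is 10000 nM, with an expected range from 4000 nM to 20000 nM.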

Compound 3, half-maximal effective concentration: > 10000 nM
Compound 3 was reported as a limit (the forecaster's own chance of this, stated with the estimate: 75%); the middle value lies on the limit itself.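

No step among compound 1, compound 2 and compound 3 can be read, because each of their values is a limit and not a number: the limit of > 10000 nM in this assay, at which 3 of the 3 values shown sit.

The compounds shown leave open whether the 2,4-dimethyl-1,3-thiazol-5-yl, hydroxymethyl and phenyl groups differ at all in this assay, as none of the three has a true value there.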